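Fluorine Position Swap on the Sulfonyl Aryl Ring

A few compounds are considered here, and "the series" means these few. Any claim that something is new, unique, unknown or untested is made for them only; others in the source may bear on it.

Measured compounds:
compound 1, `O=C(CN1CCN(S(=O)(=O)c2ccc(F)cc2)CC1)Nc1ccccc1`, 18500 nM
compound 2, `O=C(CN1CCN(S(=O)(=O)c2ccc(F)cc2)CC1)Oc1ccccc1-c1ccccc1`, 23800 nM

Both numbers come from an in vitro assay on HEK ts201 cells for negative allosteric modulation of Neuronal acetylcholine receptor; alpha3/beta4 (Homo sapiens), read by fluorescence and calcium flux, with a stated time of 1.5 s; on this read-out higher numbers stand for weaker inhibition and lower numbers for stronger inhibition. Compound 2 holds the higher of the two values, yet its gap to compound 1 falls inside the scatter, so the two cannot be ordered. Compound 3, `O=C(CN1CCN(S(=O)(=O)c2ccccc2F)CC1)Oc1ccccc1-c1ccccc1`, differs from compound 2 only in this: 2-fluorophenyl in place of 4-fluorophenyl on a sulfonyl sulfur. Among the compounds with values here, no measured pair shows what this rearrangement does, so the step from compound 2 to compound 3 is expected to be none beyond the scatter, as a 1.0-fold higher number from compound 2 to compound 3 (0.00 log units; within the scatter). Compound 3 is therefore estimated at 24000 nM, within 10000 nM to 60000 nM.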

Compound 3, half-maximal inhibitory concentration: 23500 nM
The estimate for compound 3 lay 1.0-fold (0.01 log units) above the measured number; the measured number falls inside the stated range.
By their numbers in this assay, from the lowest: compounds 1, 3 and 2 (each within the scatter of the next).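

The swap to 2-fluorophenyl in place of 4-fluorophenyl on a sulfonyl sulfur gives a 1.0-fold lower number from compound 2 to compound 3 (0.01 log units; within the scatter) in this assay, so the two fluorine placements cannot be told apart on this read-out. Within the data shown here, this is the first comparison at this position, as compound 1 and compound 2 both carry 4-fluorophenyl there. Nothing available offers an explanation for this result.

Going by these compounds, it remains open whether the same swap would read alike on the core of compound 1. Also open, on these data alone, is what an unsubstituted phenyl, a chlorine, a methoxy group or an amine on this ring would give.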